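This account rests on a few compounds, and the source may have more. Where it says the series, first, only, none or still open, it means among the compounds named here.

Compound 1 `COc1ccc(-c2cnc(NC(=O)C3CCCCC3)n2C)cc1` carries a cyclohexyl group on the carbonyl carbon of its amide. In a toxicity assay on THP-1 cells (Homo sapiens) for inhibition (a higher number here means that more compound is tolerated, a lower number that less compound is tolerated), compound 1 gives only a limit, > 100000 nM, which means the assay ran out of range before any number could be read. Two further compounds set the frame. Compound 2 `Cn1c(-c2ccccc2Br)cnc1NC(=O)c1ccc(F)cc1` likewise reaches only a limit in this assay, namely > 100000 nM. For the measured compounds named here, compound 3 `Cc1ccc(C(=O)Nc2ncc(-c3ccccc3)o2)cc1`, built on a different core, is the one compound that returns a number in this assay, 26000 nM. Compound 1 thus stands where most of the results sit: the limit of > 100000 nM in this assay, at which 2 of the 3 values shown sit.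

Compound 4 `COc1ccc(-c2cnc(NC(=O)c3cnco3)n2C)cc1` differs from compound 1 in a single place: 1,3-oxazol-5-yl in place of cyclohexyl on a carbonyl carbon. The new group is a small aromatic ring with two hetero atoms, and it takes the spot on the carbonyl carbon beside the amide-type nitrogen that the cyclohexyl held before. Going by the values given here, no pair of measured compounds shows how this kind of swap moves the read-out, so the expectation rests on compound 1 alone. In this assay the step expected is a number no higher from compound 1 to compound 4 (the limit leaves the size open), that is, nothing beyond the usual scatter. For compound 4 the expected value is therefore 100000 nM, with a range from 40000 nM to 250000 nM, and most likely the assay will again report only a limit.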

Compound 4, half-maximal cytotoxic concentration: > 100000 nM
Compound 4 ended at the assay's limit; the forecaster's own chance of this, stated with the estimate: 70%; the middle value sits exactly at the limit.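

For the compounds shown here, compound 1 and compound 4 both end at a limit rather than a number, so no step between them can be read in this assay. Compound 4 joins the group where most results now sit: the limit of > 100000 nM in this assay, at which 3 of the 4 values shown sit.

The compounds shown leave open whether 1,3-oxazol-5-yl in place of cyclohexyl changes how much compound is tolerated at all.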